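This account rests on a few compounds, and the source may have more. Where it says the series, first, only, none or still open, it means among the compounds named here.

Compound 1 `Oc1ccc(-c2cc(-c3cccc(F)c3)cc(-c3ccccc3O)n2)cc1` carries a 2-hydroxyphenyl group next to the ring nitrogen. In a functional assay on HCT-15 cells (Homo sapiens) for inhibition (on this read-out higher numbers stand for weaker inhibition and lower numbers for stronger inhibition), compound 1 reports a limit, > 50000 nM (the limit of > 50000 nM in this assay, at which 1 of the 3 values shown sits). Compound 2 `Oc1ccc(-c2cc(-c3cccc(F)c3)cc(-c3cccc(O)c3)n2)cc1` differs by 3-hydroxyphenyl in place of 2-hydroxyphenyl on an aromatic carbon; in this assay compound 2 gives 3070 nM, making the step of an at least 16-fold lower number from compound 1 to compound 2 (1.21 log units; beyond the scatter). Compound 3 `Oc1cccc(-c2cc(-c3ccccc3OC(F)(F)F)cc(-c3ccccc3O)n2)c1` keeps the 2-hydroxyphenyl group; the difference between its core and that of compound 1 is not broken down here. In this assay compound 3 gives 3240 nM, a value within the scatter of compound 2. Compound 4 `Oc1cccc(-c2cc(-c3ccccc3OC(F)(F)F)cc(-c3cccc(O)c3)n2)c1` is reached from compound 3 by 3-hydroxyphenyl in place of 2-hydroxyphenyl on an aromatic carbon. This is the same kind of change as from compound 1 to compound 2, though the place now lies meta to a 3-hydroxyphenyl group and meta to a large group rather than meta to a 3-fluorophenyl group and meta to a 4-hydroxyphenyl group. A step of a 6.5-fold lower number from compound 3 to compound 4 (0.81 log units; beyond the scatter) is expected, set beside an at least 16-fold lower number from compound 1 to compound 2 (1.21 log units; beyond the scatter) but held smaller. That earlier step rests on the limit reported for compound 1. Compound 4 is therefore expected to give 500 nM, between 120 nM and 2500 nM.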

Compound 4, half-maximal inhibitory concentration: 4220 nM
Compound 4: the middle estimate sits 8.4-fold (0.93 log units) below what was measured; the measured number lies above the stated range.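

In this assay the change from 2-hydroxyphenyl to 3-hydroxyphenyl gives a 1.3-fold higher number from compound 3 to compound 4 (0.11 log units; within the scatter), whereas on the core of compound 1 the same change gave a much larger step, so its effect did not carry from one core to the other: the same change on two cores in this assay, an at least 16-fold lower number (1.21 log units; beyond the scatter) from compound 1 to compound 2 and a 1.3-fold higher number (0.11 log units; within the scatter) from compound 3 to compound 4, at least 21-fold (1.32 log units) apart, beyond the scatter of two such steps. The earlier step rests on compound 1, whose value is a limit and not a number: the limit of > 50000 nM in this assay, at which 1 of the 4 values shown sits. The two cores differ in more than the changed group, and the pairs shown do not tell which part of them sets this gap.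

The compounds shown leave open how the change would run on a third core. They also leave open whether an amine or a carboxylic acid in place of the hydroxyl of the 3-hydroxyphenyl group would follow either core.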